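Methyl in place of 4-fluorophenyl on a sulfonyl sulfur

The source may report more compounds than this note shows. Statements on the series, on what has been measured and on what is new or still open speak of the compounds shown alone.

Of the compounds shown here, three have been measured in a functional assay on A549 cells (Homo sapiens) for antiproliferative activity, read by MTT assay, with a stated time of 48 h; a higher number here means a weaker inhibitor, a lower number a stronger inhibitor. Compound 1 `O=c1cc(-n2cc(COc3ccccc3)nn2)c2cc(Br)ccc2o1` gives 12300 nM. Compound 2 `Nc1ccc(OCc2cn(-c3cc(=O)oc4ccc(Br)cc34)nn2)cc1` gives 11900 nM. Among the compounds with values here, the only measured step, a 1.0-fold lower number from compound 1 to compound 2 (0.01 log units; within the scatter), concerns an amino group and lies within the scatter. Compound 3 `O=c1cc(-n2cc(COc3ccccc3)nn2)c2ccc(OS(=O)(=O)c3ccc(F)cc3)cc2o1` reaches only the limit of the assay: in this assay compound 3 gives > 50000 nM, a limit and not a number, as the limit of > 50000 nM in this assay, at which 1 of the 3 values shown sits, records.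

Compound 4 `CS(=O)(=O)Oc1ccc2c(-n3cc(COc4ccccc4)nn3)cc(=O)oc2c1` differs from compound 3 by methyl in place of 4-fluorophenyl on a sulfonyl sulfur. Within the data shown here, no measured step touches a sulfonyl sulfur; the one step available, a 1.0-fold lower number from compound 1 to compound 2 (0.01 log units; within the scatter), sits elsewhere in the molecule and was within the scatter, so it offers no guidance on size or direction here. Since compound 3 stands at the limit, any step can only be read if compound 4 returns a number. Compound 4 is expected to remain weak, with an estimated step of an at least 1.1-fold lower number from compound 3 to compound 4 (0.04 log units; that floor lies within the scatter). In this assay compound 4 is estimated at 45000 nM, expected between 15000 nM and 150000 nM, and a second limit is quite possible.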

Compound 4, half-maximal inhibitory concentration: 9140 nM
The estimate for compound 4 lay 4.9-fold (0.69 log units) above the measured number, and the stated range ends above it.
By their numbers in this assay, from the lowest: compounds 4, 2 and 1 (each within the scatter of the next). At a limit, above all of these: compound 3.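

Within the data shown here, replacing 4-fluorophenyl with methyl on the sulfonyl sulfur gives the first step at this position that lies beyond the scatter: in this assay, the change produces an at least 5.4-fold lower number from compound 3 to compound 4 (0.73 log units; beyond the scatter). Among these compounds, the earlier step concerned an amino group elsewhere in the molecule and stayed within the scatter, so only this pair shows that the group on the sulfonyl sulfur can change the read-out. The full size of the step remains unknown because one end of it is not a number: the limit of > 50000 nM in this assay, at which 1 of the 4 values shown sits.

The compounds shown carry only these two groups on the sulfonyl sulfur, so they cannot separate the part played by the phenyl ring from that of the fluorine, as a plain phenyl group could, or show how an ethyl group or a longer chain would behave. They also leave open whether the methyl in place of 4-fluorophenyl would give a similar step in a compound that also carries the amino group of compound 2.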